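This account rests on a few compounds, and the source may have more. Where it says the series, first, only, none or still open, it means among the compounds named here.

Compound 1, `C[C@H](NC(=O)Nc1ccccc1Cl)c1ccccc1`, and compound 3, `C[C@H](NC(=O)Nc1ccccc1Br)c1ccccc1`, share a core and differ only in one halogen on the aromatic ring: bromo in place of chloro on an aromatic carbon. In an ADME assay on the whole organism with Oryza sativa as the target, tested at 1 uM (a higher number here means a weaker effect of the compound at the concentration tested, a lower number a stronger effect), compound 1 gives 104%, and compound 3 gives 99%, so that a number 5 percentage points lower from compound 1 to compound 3 (within the scatter). Compound 2, `C[C@@H](NC(=O)Nc1cccc(Cl)c1)c1ccccc1`, is built from the same atoms as compound 1 joined differently; how the two cores differ is not broken down here. In this assay compound 2 gives 91%, a number beyond the scatter from compound 1 and within it from compound 3. Compound 4, `C[C@@H](NC(=O)Nc1cccc(Br)c1)c1ccccc1`, has not yet been tested. It stands to compound 2 as compound 3 stands to compound 1: bromo in place of chloro on an aromatic carbon. The change is the same kind of change, but the place differs: in compound 3 the bromo is ortho to a large group, in compound 4 it is meta to a large group. Since the same kind of change from compound 1 to compound 3 gave only a number 5 percentage points lower from compound 1 to compound 3 (within the scatter), the step from compound 2 to compound 4 is expected to be about as small, namely a number 3 percentage points lower from compound 2 to compound 4 (within the scatter). Compound 4 is therefore estimated at 88%, expected to lie between 76% and 100%.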

Compound 4, a percentage reported as activity, at one concentration (the size of the read-out at that concentration, not a potency): 100%
Compound 4: middle estimate off by 12 percentage points, on the low side, within the range that was stated.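

In this assay, putting bromo in place of chloro gives a number 9 percentage points higher from compound 2 to compound 4 (within the scatter). Going by these compounds alone, the step on the other core cannot be told apart from this one: the same change on two cores in this assay, a number 5 percentage points lower (within the scatter) from compound 1 to compound 3 and a number 9 percentage points higher (within the scatter) from compound 2 to compound 4, 14 percentage points apart, within the scatter of two such steps On these two cores, then, the swap carries over as a step too small to read, but that does not show that chloro and bromo are interchangeable in general, and with only two pairs, where the halogen also sits in a different place, the role of the core cannot be separated from the role of that place.

The compounds shown carry only chloro or bromo on this aromatic ring, which leaves open how the read-out would respond to a different group there, such as fluoro, methoxy, an amine or a carboxylic acid. As far as these compounds go, whether the same swap would stay as small at other places on the ring also remains open.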